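The source may hold more compounds than are shown below. What is called first, only, known or untested is meant among the compounds shown, and "the series" means these compounds.

Compound 1, `COc1ccc(-c2cc(=O)c3c(OC)cc(OC)cc3n2S(=O)(=O)c2ccc([N+](=O)[O-])cc2)cc1`, gives 17300 nM in a functional assay on KOPN-8 cells (Homo sapiens) for antiproliferative activity, with a stated time of 72 h; on this read-out lower numbers stand for an effect already at smaller amounts and higher numbers for an effect only at larger amounts of compound.
Compound 2, `COc1cc(OC)c2c(=O)cc(C(=O)Nc3cccc(N4CCCC4)c3)[nH]c2c1`, gives > 58600 nM on this assay.

Within the data shown here, the value for compound 2 is a limit of the assay, not a measured number; it tells only that compound 2 shows no effect up to that amount. Compound 2 thus stands at the limit of > 58600 nM in this assay, at which 1 of the 2 values shown sits, the weaker end of the two values shown.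

Compound 3, `COc1cc(OC)c2c(=O)cc(C(=O)Nc3cccc(-n4ccnc4)c3)[nH]c2c1`, differs from compound 2 in one place: 1H-imidazol-1-yl in place of pyrrolidin-1-yl on an aromatic carbon. Both groups are five-membered rings attached through nitrogen, so the change is a small one by size and weight. Among the measured compounds shown here, no measured step between related pairs is available to guide the expectation, and compound 2 itself gives only a limit. The step from compound 2 to compound 3 is therefore expected to stay within the scatter, with compound 3 also likely to give only a limit; the expected step is a step that the limit leaves unreadable from compound 2 to compound 3. Compound 3 is estimated at 60000 nM, between 20000 nM and 150000 nM.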

Compound 3, half-maximal effective concentration: > 16300 nM
Compound 3: a limit, no number (the forecaster's own chance of this, stated with the estimate: 70%); the middle value lies beyond the limit too.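

Compound 2 and compound 3 each give only a limit in this assay, so no step can be read between them. Still open, from the compounds shown here alone, is whether 1H-imidazol-1-yl in place of pyrrolidin-1-yl changes the effect at all, and at what amount either compound would act.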